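Moving the chlorine on the benzyl group: series notes

The source may report more compounds than this note shows. Statements on the series, on what has been measured and on what is new or still open speak of the compounds shown alone.

- compound 1 `CN(C)Cc1ccc2nc(NC(=O)N/N=C/c3cn(Cc4ccccc4Cl)c4ccccc34)sc2c1` gives 1180 nM
- compound 2 `CCN(CC)Cc1ccc2nc(NC(=O)N/N=C/c3cn(Cc4ccc(Cl)cc4)c4ccccc34)sc2c1` gives 2570 nM

The read-out for the series is a functional assay on MDA-MB-231 cells (Homo sapiens) for cytotoxicity, read by MTT assay, with a stated time of 72 h (on this read-out higher numbers stand for weaker inhibition and lower numbers for stronger inhibition), throughout. Compound 2 stands highest of the two at 2570 nM and the gap down to compound 1 lies beyond the scatter.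

Next comes compound 3 `CCN(CC)Cc1ccc2nc(NC(=O)N/N=C/c3cn(Cc4ccccc4Cl)c4ccccc34)sc2c1`, which differs from compound 2 by 2-chlorophenyl in place of 4-chlorophenyl on a saturated chain carbon bound to an aromatic nitrogen in the form of 2-chlorophenyl in place of 4-chlorophenyl on a saturated chain carbon bound to an aromatic nitrogen.

Among the measured compounds shown here, no step between measured compounds differing in one place is available, so any size stays a rough expectation. A small move toward a lower number in this assay is expected, possibly not beyond the scatter, with compound 1 at 1180 nM as the only other reference. The estimate amounts to an expected 1.4-fold lower number from compound 2 to compound 3 (0.15 log units; within the scatter) overall. The estimated value for compound 3 is 1800 nM with an expected range of 800 nM to 4000 nM for the measurement.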

Compound 3, half-maximal inhibitory concentration: 900 nM
For compound 3 the middle estimate is 2.0-fold (0.30 log units) above the measured one, and the stated range covers the measured number.
By their numbers in this assay, from the lowest: compounds 3 and 1 (each within the scatter of the next); then compound 2.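

In this assay, among the compounds shown here, 2-chlorophenyl in place of 4-chlorophenyl on a saturated chain carbon bound to an aromatic nitrogen gives a 2.9-fold lower number from compound 2 to compound 3 (0.46 log units; beyond the scatter) with the diethylamino group held fixed, the first single-place change and one that shows this place responds to where the chlorine sits. Diethylamino in place of dimethylamino on a saturated chain carbon bound to an aromatic carbon gives a 1.3-fold lower number from compound 1 to compound 3 (0.12 log units; within the scatter) with the 2-chlorophenyl group held fixed, so this pair does not separate the two amines. No measurement at hand explains either step.

The compounds shown leave open how a 3-chlorophenyl group, or an unsubstituted phenyl or a 2-fluorophenyl group, would read at the same place. They also leave open whether a cyclic amine such as morpholine or pyrrolidine would read differently from diethylamino.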